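The source may report more compounds than this note shows. Statements on the series, on what has been measured and on what is new or still open speak of the compounds shown alone.

Measured compounds in the series:

compound 1, `COC(=O)[C@@]1(C)CCC=C2[C@@H]1CC[C@@H](C)[C@]2(C)Cc1c[nH]c2ccc(Cl)cc12`: 11000 nM
compound 2, `COC(=O)[C@@]1(C)CCC=C2[C@@H]1CC[C@@H](C)[C@]2(C)Cc1c(C)[nH]c2ccccc12`: 11000 nM
compound 3, `COC(=O)[C@@]1(C)CCC=C2[C@@H]1CC[C@@H](C)[C@]2(C)Cc1c(C)[nH]c2ccc(Br)cc12`: 11000 nM

All three were run in a functional assay on HeLa cells (Homo sapiens) for inhibition, read by sulforhodamine B assay, with a stated time of 48 h; on this read-out lower numbers stand for stronger inhibition of growth and higher numbers for weaker inhibition of growth. Compound 3 stands level with compound 1 and compound 2 at the digits shown; none of the three is set apart from the others beyond the scatter. Among the compounds with values here, the only single-point step among them is no change at the digits printed from compound 2 to compound 3 (within the scatter), so adding a bromo to the ring of compound 2 left the read-out where it was.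

Compound 4, `COC(=O)[C@@]1(C)CCC=C2[C@@H]1CC[C@@H](C)[C@]2(C)Cc1c(C)[nH]c2ccc(Cl)cc12`, differs from compound 3 by chloro in place of bromo on an aromatic carbon. The step from compound 2 to compound 3 bears on this directly, since it concerns the same position on the same ring and was flat. Within the data shown here, compound 1 also carries a chloro at this position, though without the methyl on the five-membered ring, and its value matches that of compound 3; no single step links compound 1 to compound 3, so this is noted only as what the two values show.

Against this background the swap of one halogen for another is expected to move this assay by no more than the scatter: the step of no change at the digits printed from compound 3 to compound 4 (within the scatter) is estimated as essentially flat. Compound 4 is therefore expected to give about 11000 nM, with a range of 5500 nM to 22000 nM.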

Compound 4, concentration for 50% growth inhibition: 12000 nM
Compound 4: the middle estimate sits 1.1-fold (0.04 log units) below what was measured; the measured number falls inside the stated range.
By their numbers in this assay, from the lowest: compounds 1, 2, 3 and 4 (each within the scatter of the next).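

In this assay, within the data shown here, chloro in place of bromo gives a 1.1-fold higher number from compound 3 to compound 4 (0.04 log units; within the scatter), the first direct exchange of one halogen for another on this aromatic carbon of the six-membered ring, and the two halogens are not told apart. Chloro in place of hydrogen at the same position gives a 1.1-fold higher number from compound 2 to compound 4 (0.04 log units; within the scatter), and beside the bromo step no change at the digits printed from compound 2 to compound 3 (within the scatter) this shows that neither halogen is separated from hydrogen here when the methyl is present on the five-membered ring. Adding a methyl gives a 1.1-fold higher number from compound 1 to compound 4 (0.04 log units; within the scatter), so a second place on the shared core also stays within the scatter, in this case with chloro present.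

Still open, as far as these compounds go, is whether a group of another kind at the halogen position, such as an amine, a carboxylic acid or a longer chain, would move the read-out beyond the scatter, or whether this position is insensitive to change more generally. No supporting measurement is available to explain why these steps are flat.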